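Chalcone arm reversal on the shared core

A few compounds are considered here, and "the series" means these few. Any claim that something is new, unique, unknown or untested is made for them only; others in the source may bear on it.

For the measured compounds named here, compound 2 `COc1ccc(-c2cc(/C=C/C(=O)c3ccccc3)nc3cc(-c4ccccc4)nn23)cc1OC` stands at the higher end of the two numbers so far: in a functional assay on MDA-MB-231 cells (Homo sapiens) for antiproliferative activity, read by MTT assay, with a stated time of 24 h (a higher number here means a weaker inhibitor, a lower number a stronger inhibitor), compound 2 gives 11800 nM, while compound 1 `COc1ccc(-c2cc(/C=C/C(=O)c3cc(OC)c(OC)c(OC)c3)nc3cc(-c4ccccc4)nn23)cc1OC` gives 4700 nM. Going by the values given here, the single step between them, a 2.5-fold higher number from compound 1 to compound 2 (0.40 log units; beyond the scatter), is modest but beyond the scatter. Compound 3 `COc1ccc(-c2cc(C(=O)/C=C/c3ccc(Cl)cc3)nc3cc(-c4ccccc4)nn23)cc1OC` is the next member to be measured. It differs from compound 2 in the chain carried on the shared core: (2-(4-chlorophenyl)ethenyl)carbonyl in place of 2-benzoylethenyl on an aromatic carbon. This reverses the carbonyl and the ethenyl within the chain and adds a chlorine to the aromatic ring at the chain's end. Among the compounds with values here, no measured step bears directly on this change; the only known step, from compound 1 to compound 2, concerns the aromatic ring on the carbonyl carbon and not the order of the chain, so it gives only a loose hint of how much an aryl change on this arm can move the number. The number for compound 3 is therefore expected to sit close to that of compound 2, with a small expected step of a 1.5-fold lower number from compound 2 to compound 3 (0.17 log units; within the scatter) and wide uncertainty. The estimate for compound 3 in this assay is 8000 nM, within a range from 3000 nM to 25000 nM.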

Compound 3, half-maximal inhibitory concentration: 23700 nM
For compound 3 the middle estimate is 3.0-fold (0.47 log units) below the measured one; measured number inside the range.
By their numbers in this assay, from the lowest: compound 1; then compounds 2 and 3 (each within the scatter of the next).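

For the compounds shown here, the step from the benzoylethenyl chain to the reversed chain, a 2.0-fold higher number from compound 2 to compound 3 (0.30 log units; within the scatter) in this assay, is the first reading on the order of the carbonyl and the ethenyl at this position, and it shows that this pair cannot be told apart in the assay: the shared core carries either chain without a step beyond the scatter. The earlier step concerned only the aromatic ring on the carbonyl carbon, so this is also the first sign that the chain itself can be rebuilt at this place, on the aromatic carbon next to the ring nitrogen, with the number staying within the scatter, although the reversal and the added chlorine arrive together in a single step. Nothing at hand gives a measured reason for this result.

The compounds shown leave open how the step divides between the reversal and the chlorine, which would take the reversed chain with a plain phenyl end or the original chain with a 4-chlorophenyl end. Also open, going by these compounds, is how the reversed chain responds to a 3,4,5-trimethoxyphenyl end, or to a dimethylamino group or a carboxylic acid in place of the chlorine.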